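The source may report more compounds than this note shows. Statements on the series, on what has been measured and on what is new or still open speak of the compounds shown alone.

For the measured compounds named here, compound 2 `CC(=O)OC[C@H]1O[C@@H](n2cc(-c3cc(-c4ccccc4)no3)c(=O)[nH]c2=O)C[C@@H]1OC(C)=O` gives 95% in a functional assay on MDA-MB-231 cells (Homo sapiens) for cytotoxicity, read by sulforhodamine B assay, tested at 10 uM (a lower number here means less inhibition, a higher number more inhibition at the concentration tested (going by the name of the read-out)), and the only other compound measured, compound 1 `CCCc1cc(-c2cn([C@H]3C[C@H](OC(C)=O)[C@@H](COC(C)=O)O3)c(=O)[nH]c2=O)on1`, gives 102% there; the two stand within the scatter of each other, so their inhibition in this assay is level. Compound 3 `CCCCc1ccc(-c2cc(-c3cn([C@H]4C[C@H](OC(C)=O)[C@@H](COC(C)=O)O4)c(=O)[nH]c3=O)on2)cc1` differs from compound 2 by butyl in place of hydrogen on an aromatic carbon. Going by the values given here, the single measured step, a number 7 percentage points lower from compound 1 to compound 2 (within the scatter), exchanged propyl for phenyl on the same core and stayed within the scatter, so no change beyond the scatter is expected in this assay. Compound 3 is therefore expected to give 95%, between 84% and 104%, an expected step of no change at the digits printed from compound 2 to compound 3 (within the scatter).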

Compound 3, a percentage reported as inhibition, at one concentration (the size of the read-out at that concentration, not a potency): 72.2%
Compound 3: the middle estimate sits 22.8 percentage points above what was measured; the measured number lies below the stated range.
By their numbers in this assay, from the lowest: compound 3; then compounds 2 and 1 (each within the scatter of the next).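

In this assay, this position on the shared core responds to substitution: butyl on an aromatic carbon, para to a large group, gives a number 22.8 percentage points lower from compound 2 to compound 3 (beyond the scatter), whereas phenyl in place of propyl had stayed within the scatter. The change of propyl to 4-butylphenyl gives a number 29.8 percentage points lower from compound 1 to compound 3 (beyond the scatter), so among these compounds only the one carrying the butyl stands apart. Nothing available explains this drop. From the compounds shown here alone, whether it depends on chain length remains open, as does how a methyl, a longer chain, an amine or a carboxylic acid at that place would read.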